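Moving the fluorine on the benzoyl ring of compound 2

A few compounds are considered here, and "the series" means these few. Any claim that something is new, unique, unknown or untested is made for them only; others in the source may bear on it.

Compound 1 `O=C(O)CCC(=O)N(C1CC1)[C@H]1c2ccccc2N(C(=O)c2ccc(OC(F)(F)F)cc2)[C@H]2CC[C@H]21`: 4 nM
Compound 2 `O=C(O)CCC(=O)N(C1CC1)[C@H]1c2ccccc2N(C(=O)c2ccc(F)cc2)[C@H]2CC[C@H]21`: 7.3 nM

Both values come from an assay on cells for displacement of a labelled ligand from prostaglandin D2 receptor 2 (Homo sapiens), read by scintillation counting, with a stated time of 60 min; on this read-out lower numbers stand for stronger inhibition and higher numbers for weaker inhibition. For the measured compounds named here, compound 2 gives the higher of the two numbers, yet the one step measured, a 1.8-fold higher number from compound 1 to compound 2 (0.26 log units; within the scatter), lies within the scatter, so compound 2 and compound 1 are not separated. Compound 3 `O=C(O)CCC(=O)N(C1CC1)[C@H]1c2ccccc2N(C(=O)c2cccc(F)c2)[C@H]2CC[C@H]21` differs from compound 2 by 3-fluorophenyl in place of 4-fluorophenyl on a carbonyl carbon. Going by the values given here, no measured step bears on this change; the only step known concerns the substituent, not its position. Compound 3 is therefore expected to stay near compound 2, with a 1.4-fold higher number from compound 2 to compound 3 (0.14 log units; within the scatter) estimated, giving an expected 10 nM within 4 nM to 30 nM.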

Compound 3, inhibition constant: 8.1 nM
Compound 3: middle estimate off by 1.2-fold (0.09 log units), on the high side; measured number inside the range.
By their numbers in this assay, from the lowest: compounds 1, 2 and 3 (each within the scatter of the next, the first and the last beyond it).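

In this assay, the step for shifting the fluorine, a 1.1-fold higher number from compound 2 to compound 3 (0.05 log units; within the scatter), shows that compounds 2 and 3 are not separated, so this move on the carbonyl carbon leaves the number unresolved from that of compound 2. For the compounds shown here, the wider change gives a 2.0-fold higher number from compound 1 to compound 3 (0.31 log units; beyond the scatter), the first step in this set to lie beyond the scatter, though only modestly. No measurement available here explains either step. Still open, from the compounds shown here alone, is how 3-chlorophenyl, 3-methoxyphenyl or a pyridine ring would read on that carbonyl carbon.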